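The compounds below may be only part of what the source reports. "The series", "measured", "known", "first", "only" and "open" are said of these compounds alone.

Two compounds of a shared core have been examined in an ADME assay on HeLa cells (Homo sapiens) for cytotoxicity, read by MTT assay; on this read-out higher numbers stand for weaker inhibition and lower numbers for stronger inhibition. Compound 1 `CCN(CC)C(=O)CCC(=O)Oc1ccc(C[C@H]2C(=O)OC[C@@H]2Cc2ccc(OC)c(OC)c2)cc1OC`, which carries an ester-linked amide chain on one aromatic ring, gives 213000 nM in this assay. Compound 2 `COc1ccc(C[C@H]2COC(=O)[C@@H]2Cc2ccc(OCc3cn(Cc4ccccc4)nn3)c(OC)c2)cc1OC` gives 346000 nM in this assay, the highest of the two numbers, though its separation from compound 1 lies within the scatter, so the two values cannot be ordered against each other.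

Compound 3 `COc1ccc(C[C@H]2COC(=O)[C@@H]2Cc2ccc(OCC(=O)N3CCOCC3)c(OC)c2)cc1OC` has not yet been measured in this assay. It differs from compound 2 in one place: (morpholin-4-yl)carbonyl in place of 1-benzyl-1H-1,2,3-triazol-4-yl on a saturated chain carbon bound to an oxygen on an aromatic ring. Among the compounds with values here, no step between two measured compounds describes such a change, so the expectation rests only on the two values shown, which sit close together in spite of the unrelated groups at this position. Compound 3 is therefore expected to stay near compound 2, with a step from compound 2 to compound 3 of a 1.2-fold lower number from compound 2 to compound 3 (0.06 log units; within the scatter), which is no more than the scatter. The estimate for compound 3 in this assay is 300000 nM, within a range from 150000 nM to 600000 nM.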

Compound 3, half-maximal inhibitory concentration: >= 600000 nM
Compound 3 ended at the assay's limit; the forecaster's own chance of this, stated with the estimate: 20%; at least 2.0-fold (0.30 log units) between middle value and limit.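

In this assay compound 3 stands at a limit of the assay and not at a number: the limit of >= 600000 nM in this assay, at which 1 of the 3 values shown sits.

Putting (morpholin-4-yl)carbonyl in place of 1-benzyl-1H-1,2,3-triazol-4-yl on a saturated chain carbon bound to an oxygen on an aromatic ring gives an at least 1.7-fold higher number from compound 2 to compound 3 (0.23 log units; that floor lies within the scatter), so this floor alone does not separate the two compounds. The comparison with compound 1, where a group of 9 heavy atoms with a six-membered non-aromatic ring replaces a group of 11 heavy atoms with no ring on an oxygen on an aromatic ring, gives an at least 2.8-fold higher number from compound 1 to compound 3 (0.44 log units; beyond the scatter); unlike the two earlier values, which could not be ordered, this step shows that a change at this position can shift the number towards weaker inhibition.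

From the compounds shown here alone, how far compound 3 actually lies beyond the limit remains open, and with it the true size of both steps. Also open, going by these compounds, is whether a simple amine or a carboxylic acid in place of the (morpholin-4-yl)carbonyl, or a longer chain carrying it, would stay at this limit or return to the range of compound 1 and compound 2.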